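A few compounds are considered here, and "the series" means these few. Any claim that something is new, unique, unknown or untested is made for them only; others in the source may bear on it.

Compound 1 `O=C(O)CCc1cccc2c1B(O)OC2` has the value > 100000 nM in an ADME assay on WI-38 cells (Homo sapiens) for cytotoxicity, read by MTT assay, with a stated time of 72 h (a lower number here means a stronger inhibitor, a higher number a weaker inhibitor), which is a limit of the assay rather than a number.
Compound 2 `Cc1ccc(NC(=O)CCc2cccc3c2B(O)OC3)cc1Br` gives 15000 nM.
Compound 3 `O=C(CCc1cccc2c1B(O)OC2)Nc1cccc(-c2cccc(F)c2)c1` gives 37000 nM.

Of the two numbers shown, compound 3 holds the higher one, and the gap to compound 2 lies beyond the usual scatter. Compound 4 `O=C(CCc1cccc2c1B(O)OC2)Nc1cccc(-c2cccc(C(F)(F)F)c2)c1` has not yet been measured. It differs from compound 3 in one place: trifluoromethyl in place of fluoro on an aromatic carbon. Going by the values given here, no measured pair shows this same change, so there is no direct guide to its effect. The step of a 1.1-fold higher number from compound 3 to compound 4 (0.03 log units; within the scatter) is therefore expected to be small, most likely within the scatter, with no clear direction. Compound 4 is expected to give about 40000 nM, in a range from 15000 nM to 100000 nM, in this assay.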

Compound 4, half-maximal inhibitory concentration: 23000 nM
Compound 4: the middle estimate sits 1.7-fold (0.24 log units) above what was measured; measured number inside the range.
By their numbers in this assay, from the lowest: compounds 2, 4 and 3 (each within the scatter of the next, the first and the last beyond it). At a limit, above all of these: compound 1.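

In this assay trifluoromethyl in place of fluoro, on an aromatic carbon meta to a large group, gives a 1.6-fold lower number from compound 3 to compound 4 (0.21 log units; within the scatter) and so leaves the two compounds indistinguishable. This is the first pair shown that differs in one place, and it shows that here four heavy atoms can replace one with no change beyond the scatter. Nothing shown gives a reason for this result. From the compounds shown here alone, whether an amine or a carboxylic acid at this same position would also leave the number unmoved stays open.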